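The compounds below may be only part of what the source reports. "The series", "measured", "known", "first", "only" and "open" are said of these compounds alone.

Compound 1 `Cc1ccc(OCC(=O)N(Cc2cccs2)c2ncco2)cc1`: 0.3 nM
Compound 2 `Cc1ccc(OCC(=O)N(Cc2cccs2)c2nccs2)cc1`: 2240 nM
Compound 3 `Cc1ccc(OCC(=O)N(Cc2cccs2)C(C)(C)C)cc1`: 11000 nM

In an assay on HEK293 cells for agonist activity at transient receptor potential cation channel subfamily M member 8 (Homo sapiens), read by fluorescence and calcium flux, with a stated time of 15 min (on this read-out higher numbers stand for an effect only at larger amounts of compound and lower numbers for an effect already at smaller amounts), compound 3 gives the highest number of the three, so it acts only at the largest amount of compound; compound 2 comes nearest, and compound 1 lies far off. Compound 4 `C=CCN(Cc1cccs1)C(=O)COc1ccc(C)cc1` is not yet measured. It differs from compound 3 in one place: allyl in place of tert-butyl on an amide-type nitrogen. All three measured steps change the group on this same nitrogen. Two are large, a 7500-fold higher number from compound 1 to compound 2 (3.87 log units; beyond the scatter) and a 37000-fold higher number from compound 1 to compound 3 (4.56 log units; beyond the scatter), but both remove the ring of compound 1. The step that bears most directly, a 4.9-fold higher number from compound 2 to compound 3 (0.69 log units; beyond the scatter), is modest. Exchanging one group without a ring for another is expected to move the number little, so for compound 4 the step of a 1.4-fold lower number from compound 3 to compound 4 (0.14 log units; within the scatter) is expected. Compound 4 is therefore estimated at 8000 nM, within 1500 nM to 40000 nM.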

Compound 4, half-maximal effective concentration: 20 nM
Compound 4: middle estimate off by 400-fold (2.60 log units), on the high side; the whole stated range lies above it.
By their numbers in this assay, from the lowest: compound 1; then compound 4; then compound 2; then compound 3.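

Even without a ring, the group on this amide-type nitrogen can matter greatly: allyl in place of tert-butyl gives a large drop (a 550-fold lower number from compound 3 to compound 4 (2.74 log units; beyond the scatter)). Allyl also gives a lower number than the 1,3-thiazol-2-yl group (a 110-fold lower number from compound 2 to compound 4 (2.05 log units; beyond the scatter)) but a higher one than the 1,3-oxazol-2-yl group (a 67-fold higher number from compound 1 to compound 4 (1.82 log units; beyond the scatter)), so among these compounds a ring here is neither needed for a low number nor enough to give one. No supporting measurement accounts for these gaps.

On these data alone, how a propyl chain, with the carbons of allyl but not its double bond, would compare remains open, and with it whether that double bond matters. As far as these compounds go, how a longer chain or an aminoethyl group on this nitrogen would compare is equally open.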